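Amide replacement on the aryl-pyrazole series

A few compounds are considered here, and "the series" means these few. Any claim that something is new, unique, unknown or untested is made for them only; others in the source may bear on it.

Compound 1 `C[C@@H](Cn1ccc(-c2ccc(C#N)c(Cl)c2)n1)NC(=O)c1ccccc1`: 1830 nM
Compound 2 `COc1ccc(C(=O)N[C@@H](C)Cn2ccc(-c3ccc(C#N)c(Cl)c3)n2)cc1`: 3410 nM

In a functional assay on LNCaP cells (Homo sapiens) for antiproliferative activity, read by CCK-8 assay, with a stated time of 6 days (on this read-out higher numbers stand for weaker inhibition and lower numbers for stronger inhibition), compound 2 gives the highest of the two numbers, with compound 1 nearest; the step of a 1.9-fold higher number from compound 1 to compound 2 (0.27 log units; within the scatter) lies within the scatter. Compound 3 `COC(=O)/C=C/C(=O)N[C@@H](C)Cn1ccc(-c2ccc(C#N)c(Cl)c2)n1` differs from compound 2 by 2-(methoxycarbonyl)ethenyl in place of 4-methoxyphenyl on a carbonyl carbon. Among the measured compounds shown here, no measured step covers a change of this kind; the only step at hand, from compound 1 to compound 2, touches a substituent on the aryl that now leaves. The expectation therefore rests on compound 2 alone, at 3410 nM, and is broad. Compound 3 is estimated at 3000 nM (range 700 nM to 13000 nM), a step of a 1.1-fold lower number from compound 2 to compound 3 (0.06 log units; within the scatter) expected to stay within the scatter.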

Compound 3, half-maximal inhibitory concentration: 2460 nM
Estimate against measurement, compound 3: 1.2-fold (0.09 log units) above, and the stated range covers the measured number.
By their numbers in this assay, from the lowest: compounds 1, 3 and 2 (each within the scatter of the next).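

In this assay the carbonyl carbon accepts a group with no ring: with 2-(methoxycarbonyl)ethenyl entering, a 1.4-fold lower number from compound 2 to compound 3 (0.14 log units; within the scatter) and a 1.3-fold higher number from compound 1 to compound 3 (0.13 log units; within the scatter) both lie within the scatter. Among these three compounds, then, an aromatic ring on this carbonyl carbon is not required for numbers of this size. Nothing at hand explains this result.

Open, on these data alone, is whether the free carboxylic acid in place of the methyl ester keeps numbers of this size. Also open, as far as these compounds go, is whether a saturated chain can stand in for the ethenyl link.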